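Ring opened to chain on the aryl ether of compound 3

This account rests on a few compounds, and the source may have more. Where it says the series, first, only, none or still open, it means among the compounds named here.

This account follows one step in a small series sharing a common core. Compound 1 `COc1cc(OC)c2c(=O)cc(-c3ccc(OCCBr)cc3)oc2c1` and compound 2 `COc1cc(OC)c2c(=O)cc(-c3ccc(OCCF)cc3)oc2c1` carry short haloalkyl ethers; in a functional assay (Homo sapiens) for antiproliferative activity, read by resazurin assay, with a stated time of 48 h, tested at 10 uM (a lower number here means a weaker effect, a higher number a stronger effect of the compound at the concentration tested), compound 1 is reported as "not active" (no number reported) and compound 2 likewise as "not active" (no number reported), with no number given for either. Within the data shown here, compound 3 `COc1cc(OC)c2c(=O)cc(-c3ccc(OC4CCN(C)CC4)cc3)oc2c1` is the only member with a number: in this assay compound 3 gives 49%. With two entries lacking a number, compound 3 stands alone on the scale, and nothing can be said about its order relative to compound 1 or compound 2 beyond what their entries show.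

Compound 4 `COc1cc(OC)c2c(=O)cc(-c3ccc(OCCCN(C)C)cc3)oc2c1` has not yet been measured. It differs from compound 3 in one place: 3-(dimethylamino)propyl in place of 1-methylpiperidin-4-yl on an oxygen on an aromatic ring. Among the measured compounds shown here, no step between two measured compounds is known for this kind of change, so any expectation rests on compound 3 alone. The author expects the step from compound 3 to compound 4 to be small, probably within the usual scatter, leaning slightly lower: a number 9 percentage points lower from compound 3 to compound 4 (within the scatter). Compound 4 is therefore expected to give 40% in this assay, with a range from 15% to 62%.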

Compound 4, a percentage reported as inhibition, at one concentration (the size of the read-out at that concentration, not a potency): 59%
The estimate for compound 4 lay 19 percentage points below the measured number; the measured number falls inside the stated range.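

In this assay, replacing 1-methylpiperidin-4-yl with 3-(dimethylamino)propyl on an oxygen on an aromatic ring gives a number 10 percentage points higher from compound 3 to compound 4 (within the scatter), so this pair cannot be put in order, and the ring can be opened to a chain without leaving the scatter. Two nitrogen-bearing groups, one cyclic and one open-chain, now give numbers at this oxygen, while the short haloalkyl ethers of compound 1 and compound 2 stand as "not active", and steps to those two entries cannot be read. No measurement shown here accounts for how the two amine-bearing groups compare with each other or with the haloalkyl ethers.

The compounds shown leave open whether the nitrogen itself is needed, which a plain propyl ether or a chain ending in a hydroxyl group could test, and whether chain length matters, as a 2-(dimethylamino)ethyl or a longer 4-(dimethylamino)butyl chain could show. They also leave open how other amines at this oxygen, such as a morpholine or a primary amine, would read at the single concentration tested, which gives the size of the effect and not a potency.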